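The compounds below may be only part of what the source reports. "The series", "measured", "known", "first", "only" and "open" are said of these compounds alone.

Measured so far:
- compound 1, `O/N=C(/CCN1CCN(c2ccccn2)CC1)c1cc(F)cc(F)c1`: 70%
- compound 2, `CCO/N=C(\CCN1CCN(c2ccccc2OC)CC1)c1ccccc1`: 76%

Both compounds were run in a functional assay on HEK293 cells with D(4) dopamine receptor (Homo sapiens) as the target, read by FLIPR; on this read-out higher numbers stand for larger maximal responses and lower numbers for smaller maximal responses. Compound 1 reaches 70% there and compound 2 reaches 76%. The two numbers lie within the scatter of each other, so compound 2 is not set apart from compound 1 on this read-out; the pair gives two values of similar size and nothing more.

The next compound is compound 3, `CCO/N=C(\CCN1CCN(c2cccc(OCC)c2)CC1)c1ccccc1`. Relative to compound 2 the change is 3-ethoxyphenyl in place of 2-methoxyphenyl on an amine nitrogen in a ring. Within the data shown here, no measured pair in the set differs in one place, so there is no step against which to size this change. Among the measured compounds shown here, with only two values, both of similar size, no step beyond the scatter is expected in this assay in either direction, though the uncertainty is wide. Compound 3 is estimated at 70%, between 50% and 90%, meaning an expected step of a number 6 percentage points lower from compound 2 to compound 3 (within the scatter).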

Compound 3, largest response reached (reported as efficacy), in percent of the reference or control that the assay uses: 84%
Beside the measured number, compound 3's estimate is 14 percentage points below it, within the range that was stated.
By their numbers in this assay, from the lowest: compounds 1, 2 and 3 (each within the scatter of the next, the first and the last beyond it).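

Working on the amine nitrogen in a ring, 3-ethoxyphenyl in place of 2-methoxyphenyl gives in this assay a first sized step at this position: a number 8 percentage points higher from compound 2 to compound 3 (within the scatter). Among these compounds, the maximal response therefore stays in the same range through this exchange of aryl groups, although 3-ethoxyphenyl carries a larger alkoxy group and a different numbered position, and the single step cannot divide its size between those two parts. No supporting data bear on what sets the size of this step.

The compounds shown leave open how 3-methoxyphenyl and 2-ethoxyphenyl would read, which would separate the two parts of the change. Also open, going by these compounds, is whether a longer alkoxy chain, an amine or a carboxylic acid on this phenyl would produce a step beyond the scatter.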